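Replacing an Amide Amine with Morpholine: What to Expect

A few compounds are considered here, and "the series" means these few. Any claim that something is new, unique, unknown or untested is made for them only; others in the source may bear on it.

Compound 1, `CCOc1cccc2c1S(=O)(=O)N=C2C1=C(O)[C@H](C(C)C)N(Cc2ccccc2)C1=O`: in an in vitro ADME assay on microsomes from liver (Homo sapiens) for metabolic stability (on this read-out lower numbers stand for a shorter-lived compound and higher numbers for a longer-lived compound), compound 1 reaches the limit > 1 h.
Compound 2, `CC(C)[C@H]1C(O)=C(C2=NS(=O)(=O)c3c(O)cccc32)C(=O)N1Cc1ccccc1`: in this assay compound 2 reaches the limit > 1 h.
Compound 3, `CC(C)[C@H]1C(O)=C(C2=NS(=O)(=O)c3c(OCC(N)=O)cccc32)C(=O)N1Cc1ccccc1`: in this assay compound 3 reaches the limit > 1 h.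

Each of these three values is a limit of the assay, not a number: every compound outlasted the window of the measurement. Compound 3 therefore stands exactly where the other two measured compounds stand, which is what the limit of > 1 h in this assay, at which 3 of the 3 values shown sit, records. The three single changes that connect the measured compounds, a step that the two limits leave unreadable from compound 1 to compound 2, a step that the two limits leave unreadable from compound 1 to compound 3 and a step that the two limits leave unreadable from compound 2 to compound 3, are all hidden behind that same limit, so none of them can be given a size or a direction.

Compound 4, `CC(C)[C@H]1C(O)=C(C2=NS(=O)(=O)c3c(OCC(=O)N4CCOCC4)cccc32)C(=O)N1Cc1ccccc1`, differs from compound 3 in one place: morpholin-4-yl in place of amino on a carbonyl carbon. Among the compounds with values here, no measured step contains this change, and the steps that do exist offer no readable size to lean on. What the data do show is that three different groups on the same oxygen all left the compound beyond the limit. On that basis compound 4 is expected to behave like compound 3, a step that the limit leaves unreadable from compound 3 to compound 4 that should stay within the usual scatter. Compound 4 is thus expected to give about 1.5 h, with a range from 0.8 h to 4 h, and most probably to be reported once more as a limit.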

Compound 4, half-life: > 1 h
Compound 4: only a limit was reported; the forecaster's own chance of this, stated with the estimate: 75%; the middle value lies beyond the limit too.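

In this assay compound 4 gives > 1 h, which is a limit and not a number. Its steps from compound 1, compound 2 and compound 3 therefore cannot be read, and all four compounds stand together: the limit of > 1 h in this assay, at which 4 of the 4 values shown sit.

The compounds shown leave open how long each one lasts beyond that limit, and so whether morpholin-4-yl in place of amino changes the half-life at all.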